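Hydroxyamino for hydroxymethyl on the benzylamine arm

The source may hold more compounds than are shown below. What is called first, only, known or untested is meant among the compounds shown, and "the series" means these compounds.

Two compounds of the series have numbers in an assay for inhibition of Tryptophan 2,3-dioxygenase (Homo sapiens), with a stated time of 1 h, tested at 10 uM; a higher number here means more inhibition at the concentration tested (going by the name of the read-out), a lower number less inhibition. Compound 1 `Oc1cccc(CNc2cc(Br)cc3[nH]ncc23)c1` gives 55% in this assay. Compound 2 `OCc1ccc(CNc2cc(Br)cc3[nH]ncc23)cc1` gives 56% in this assay, and the gap to compound 1 lies within the scatter, so the two compounds cannot be told apart on these numbers. Both carry the same core and the same benzylamine arm; they differ only in the group on the six-membered aromatic ring of carbon only and in where it sits.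

Compound 3 `ONc1ccc(CNc2cc(Br)cc3[nH]ncc23)cc1` is not yet measured. Against compound 2 the change is hydroxyamino in place of hydroxymethyl on an aromatic carbon. The group enters on an aromatic carbon, para to a large group, where compound 2 carries the hydroxymethyl.

Among the measured compounds shown here, no step between measured compounds is known, so there is no measured precedent for this change. Given that compound 1 and compound 2 sit within the scatter of each other in this assay, the expected step from compound 2 to compound 3 is a number 4 percentage points lower from compound 2 to compound 3 (within the scatter), that is, a small one in either direction and most likely none beyond the scatter. Compound 3 is therefore estimated at 52% in this assay, with a range from 30% to 72%.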

Compound 3, a percentage reported as inhibition, at one concentration (the size of the read-out at that concentration, not a potency): 6%
Estimate against measurement, compound 3: 46 percentage points above; measured number outside the range, below it.
By their numbers in this assay, from the lowest: compound 3; then compounds 1 and 2 (each within the scatter of the next).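

In this assay, among the compounds shown here, the aromatic carbon para to a large group proves sensitive to the group it carries: hydroxyamino in place of hydroxymethyl gives a number 50 percentage points lower from compound 2 to compound 3 (beyond the scatter) and is the first readable step between compounds differing in one place. This large step comes with no change in size as counted: each group has 2 heavy atoms, no ring and no net charge, while nitrogen stands for carbon and the hydrogen-bond count goes from 1 donor and 1 acceptor to 2 donors and 2 acceptors. Nothing in hand bears on the origin of the step, which therefore stays unexplained.

From the compounds shown here alone, whether the loss belongs to the nitrogen, the oxygen or the two joined remains open, and an amine, a methoxy group or a carboxylic acid on the same aromatic carbon would begin to separate these cases. Also open, going by these compounds, is whether hydroxyamino behaves in the same way on the ring carbon where compound 1 carries its hydroxyl group.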